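The source may report more compounds than this note shows. Statements on the series, on what has been measured and on what is new or still open speak of the compounds shown alone.

In a functional assay on SW620/5-FU cells (Homo sapiens) for cytotoxicity, read by MTT assay, with a stated time of 48 h, in the presence of a further agent that is not named here (a higher number here means that more compound is needed for the effect, a lower number that less compound is needed), compound 1 `Cn1ncc2c(-c3ccc(F)cc3)cc(NNC(=O)Nc3cc(Cl)cc(Cl)c3)nc21` gives 54300 nM and compound 2 `Cn1ncc2c(-c3ccc(F)cc3)cc(NNC(=O)Nc3cc(Cl)nc(OCCF)c3)nc21` gives 29300 nM, so the two lie within the usual scatter. Compound 3 `CCCCOc1cc(NC(=O)NNc2cc(-c3ccc(F)cc3)c3cnn(C)c3n2)cc(Cl)n1` keeps the structure of compound 2 except for one change, 2-fluoroethoxy to butoxy, which means ethyl in place of fluoro on a saturated chain carbon, two bonds along the chain from an oxygen on an aromatic ring. Going by the values given here, the only measured step, a 1.9-fold lower number from compound 1 to compound 2 (0.27 log units; within the scatter), replaced 3,5-dichlorophenyl with 2-chloro-6-(2-fluoroethoxy)pyridin-4-yl and did not test this chain, so it offers only weak guidance. No shift beyond the scatter is therefore expected, and the estimated step is a 1.2-fold lower number from compound 2 to compound 3 (0.07 log units; within the scatter). The estimate for compound 3 is 25000 nM, with an expected range of 10000 nM to 60000 nM.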

Compound 3, half-maximal effective concentration: 29300 nM
Compound 3: the middle estimate sits 1.2-fold (0.07 log units) below what was measured; the measured number falls inside the stated range.
By their numbers in this assay, from the lowest: compounds 2, 3 and 1 (each within the scatter of the next).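

Compound 2 and compound 3 are the first pair shown to differ in this chain, and in this assay the swap of 2-fluoroethoxy for butoxy gives no change at the digits printed from compound 2 to compound 3 (within the scatter). At this position, therefore, ethyl in place of fluoro on a saturated chain carbon leaves the two compounds indistinguishable in this assay, and a fluorine at the chain end is not required for the activity seen here. From the compounds shown here alone, whether an amine or a carboxylic acid at the end of this chain, or a chain longer than butyl, would give a step beyond the scatter remains open. Nothing available offers an explanation for this result.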